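Amino for Cyclopropyl on a Short-Lived Pyridazine Amide

The source may report more compounds than this note shows. Statements on the series, on what has been measured and on what is new or still open speak of the compounds shown alone.

The measured compounds, each in an ADME assay on microsomes from liver (Mus musculus) for metabolic stability, read by LC-MS, using NADPH, tested at 10 uM; on this read-out higher numbers stand for a longer-lived compound and lower numbers for a shorter-lived compound:
- compound 1, `O=C(NCc1ccc(F)cc1)c1ccc(N2CCN(S(=O)(=O)c3cccnc3C3CC3)CC2)nn1`, gives 0.1 h
- compound 2, `O=C(NCc1ccccc1)c1ccc(N2CCN(S(=O)(=O)c3cccc(Cl)c3Cl)CC2)nn1`, gives 0.233 h

Compound 1 has the lower of the two numbers, and its gap to compound 2 is beyond the usual scatter, so it is the shorter-lived of the pair. Compound 3, `Nc1ncccc1S(=O)(=O)N1CCN(c2ccc(C(=O)NCc3ccc(F)cc3)nn2)CC1`, differs from compound 1 in one place: amino in place of cyclopropyl on an aromatic carbon. Among the measured compounds shown here, no pair of measured compounds shows this change, so nothing directly tells its effect. A small lengthening of half-life, barely beyond the scatter, is expected, a 1.8-fold higher number from compound 1 to compound 3 (0.26 log units; within the scatter). Compound 3 is therefore estimated at 0.18 h, within a range from 0.06 h to 0.5 h.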

Compound 3, half-life: 0.317 h
Compound 3: middle estimate off by 1.8-fold (0.25 log units), on the low side, within the range that was stated.
By their numbers in this assay, from the lowest: compound 1; then compounds 2 and 3 (each within the scatter of the next).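

Amino in place of cyclopropyl gives a 3.2-fold higher number from compound 1 to compound 3 (0.50 log units; beyond the scatter) in this assay and shows that the group on this aromatic carbon, next to the ring nitrogen, matters for half-life. Among the compounds shown here, this single pair is the first direct reading of the change, and it holds only for this core. Nothing measured here bears on the reason for the rise.

On these data alone, it remains open how a methyl, a methoxy or a dimethylamino group would compare at this position. Whether amino gives a similar step on other amides is also unknown.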